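Estimating compound 3 from two limit values

A few compounds are considered here, and "the series" means these few. Any claim that something is new, unique, unknown or untested is made for them only; others in the source may bear on it.

Measured in a functional assay on HeLa cells (Homo sapiens) for inhibition, read by CCK-8 assay, with a stated time of 48 h (a lower number here means a stronger inhibitor, a higher number a weaker inhibitor), both values being limits:
- Compound 1 `COc1cccc(NC(=S)NCCNS(=O)(=O)c2ccc(-c3ccccc3Oc3ccc([N+](=O)[O-])cc3)s2)c1` gives > 50000 nM as a limit
- Compound 2 `COc1ccc(NC(=O)NCCNS(=O)(=O)c2ccc(-c3ccccc3Oc3ccc([N+](=O)[O-])cc3)s2)cc1` gives > 20000 nM as a limit

Compound 2 has no exact number, and its entry of > 20000 nM is a limit. Compound 3 `O=[N+]([O-])c1ccc(Oc2ccccc2-c2ccc(S(=O)(=O)NCCNC(=S)Nc3cccc(Cl)c3)s2)cc1` keeps the shared core and differs from compound 2 in one place: a group of 10 heavy atoms (7 carbon, 1 nitrogen, 1 sulfur, 1 chlorine; one six-membered aromatic ring of carbon only) in place of a group of 11 heavy atoms (8 carbon, 1 nitrogen, 2 oxygen; one six-membered aromatic ring of carbon only), on an amine nitrogen. The (4-methoxyphenyl)carbamoyl group leaves, and a group with no common name, containing sulfur and chlorine, enters on the same amine nitrogen.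

Going by the values given here, only one measured step bears on this change. It is a step that the two limits leave unreadable from compound 1 to compound 2, which also exchanges a group on an amine nitrogen. With a limit at each end, that step offers no size or direction to carry over. The expectation therefore rests on the limit of compound 2 at > 20000 nM in this assay, and compound 3 is expected to stay in the same high range. The expected change is a step that the limit leaves unreadable from compound 2 to compound 3, an estimate with no firm direction. For compound 3 the estimated value is 30000 nM, with an expected range from 8000 nM to 80000 nM.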

Compound 3, half-maximal inhibitory concentration: 4600 nM
Compound 3: middle estimate off by 6.5-fold (0.81 log units), on the high side, outside the stated range (below it).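

Going by these compounds alone, the group on the amine nitrogen turns out to matter in this assay, since compound 3 is the first compound here with an exact value, and exchanging the (4-methoxyphenyl)carbamoyl group for the sulfur- and chlorine-containing group gives an at least 4.3-fold lower number from compound 2 to compound 3 (0.63 log units; beyond the scatter). The narrower change, chloro in place of methoxy on an aromatic carbon, is enough by itself to give an at least 10-fold lower number from compound 1 to compound 3 (1.03 log units; beyond the scatter), which shows that this single substituent can separate a compound with an exact value from one without. That size is only a minimum because compound 1 carries a limit: the limit of > 50000 nM in this assay, at which 1 of the 3 values shown sits.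

As far as these compounds go, the step from compound 1 to compound 2 cannot be read, with a limit at each end, and the group exchanged between compound 2 and compound 3 brings in both sulfur and chlorine, so the share of each in that step remains unknown. Also open, from the compounds shown here alone, is how a bromo or a methyl group in place of the chloro would read, and whether a longer chain on the amine nitrogen would keep the value of compound 3.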